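Bromochalcone triazole series: positional bromide swap on nitro analogue

The source may hold more compounds than are shown below. What is called first, only, known or untested is meant among the compounds shown, and "the series" means these compounds.

Measured compounds:
Compound 1, `O=C(/C=C/c1ccc(OCc2cn(Cc3cccc(Br)c3)nn2)cc1)c1ccc(Br)cc1`, in a functional assay on MIA PaCa-2 cells (Homo sapiens) for inhibition, read by MTT assay, with a stated time of 48 h, tested at 10 uM (a lower number here means less inhibition of growth, a higher number more inhibition of growth at the concentration tested), gives 43%.
Compound 2, `O=C(/C=C/c1ccc(OCc2cn(Cc3ccc(Br)cc3)nn2)cc1)c1ccc(Br)cc1`, in this assay gives 29%.
Compound 3, `O=C(/C=C/c1ccc(OCc2cn(Cc3cccc(Br)c3)nn2)cc1)c1ccc([N+](=O)[O-])cc1`, in this assay gives 21%.

Compound 1 stands highest of the three measured values. Moving from compound 1 to compound 2 is the change (4-bromophenyl in place of 3-bromophenyl on a saturated chain carbon bound to an aromatic nitrogen), and it gives a number 14 percentage points lower from compound 1 to compound 2 (beyond the scatter). Moving from compound 1 to compound 3 is the change (nitro in place of bromo on an aromatic carbon), and it gives a number 22 percentage points lower from compound 1 to compound 3 (beyond the scatter). Compound 3 is the lowest of the three values; its gap to compound 2 lies within the scatter, so no order between compound 2 and compound 3 is claimed.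

Compound 4, `O=C(/C=C/c1ccc(OCc2cn(Cc3ccc(Br)cc3)nn2)cc1)c1ccc([N+](=O)[O-])cc1`, has not been measured. It differs from compound 3 by 4-bromophenyl in place of 3-bromophenyl on a saturated chain carbon bound to an aromatic nitrogen, the same change that was made from compound 1 to compound 2; the place line is identical in both cases. The cores of the two pairs differ by nitro in place of bromo on an aromatic carbon.

Going by the values given here, in the one measured instance the change lowered the value by a modest amount, recorded as a number 14 percentage points lower from compound 1 to compound 2 (beyond the scatter). A step of the same sign is expected from compound 3 to compound 4, estimated as a number 11 percentage points lower from compound 3 to compound 4 (beyond the scatter), smaller in size because compound 3 already starts from 21%, a low value in this read-out. The expected value for compound 4 in this assay is therefore 10%, with an estimated range from 0% to 25%.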

Compound 4, percent growth inhibition at one concentration: 17%
For compound 4 the middle estimate is 7 percentage points below the measured one; low and high end bracket the measured number.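

The swap of 3-bromophenyl for 4-bromophenyl on the saturated chain carbon bound to an aromatic nitrogen gives a number 4 percentage points lower from compound 3 to compound 4 (within the scatter) on the nitro core, and in this assay its size does not differ between the two cores: the same change on two cores in this assay, a number 14 percentage points lower (beyond the scatter) from compound 1 to compound 2 and a number 4 percentage points lower (within the scatter) from compound 3 to compound 4, 10 percentage points apart, within the scatter of two such steps. Nitro in place of bromo on an aromatic carbon gives a number 12 percentage points lower from compound 2 to compound 4 (beyond the scatter) with the 4-bromophenyl group in place, and this step also does not differ from its earlier reading: the same change on two cores in this assay, a number 22 percentage points lower (beyond the scatter) from compound 1 to compound 3 and a number 12 percentage points lower (beyond the scatter) from compound 2 to compound 4, 10 percentage points apart, within the scatter of two such steps. Both changes therefore carry from one core to the other without a detectable difference in step size, but two cores cannot show that the steps are generally transferable or strictly additive, and on the nitro core the bromophenyl swap alone does not stand clear of the scatter.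

Still open, going by these compounds, is whether either step holds with an amine or a carboxylic acid on that aromatic carbon in place of bromo or nitro, or with a longer chain in place of the single saturated carbon bearing the bromophenyl group. Each reading also comes from one concentration in one cell line, so the behaviour of these compounds at other concentrations and in other cells remains open too.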